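The source may hold more compounds than are shown below. What is called first, only, known or untested is meant among the compounds shown, and "the series" means these compounds.

Measured so far:
compound 1 `CCOC(=O)c1cc(Cn2ccc(=O)c3ccc(C(F)(F)F)cc32)on1` gives "not determined" (no result reported)
compound 2 `CCOC(=O)c1cc(COc2ccnc3cc(C(F)(F)F)ccc23)on1` gives "not determined" (no result reported)
compound 3 `CCOC(=O)c1cc(COc2cc(C(F)(F)F)nc3c(C(F)(F)F)cc(OC)cc23)on1` gives > 128000 nM (a limit of the assay, not a number)

In an ADME assay on Vero cells (Chlorocebus sabaeus) for cytotoxicity, with a stated time of 72 h (on this read-out lower numbers stand for stronger inhibition and higher numbers for weaker inhibition), compound 2 gives "not determined" (no result reported) and so has no single number to stand on. Within the data shown here, the only reading nearby is the limit of > 128000 nM in this assay, at which 1 of the 3 values shown sits, and that is a limit.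

Compound 4 (`CCOC(=O)c1cc(COc2ccnc3ccccc23)on1`) has not yet been measured. The change hydrogen in place of trifluoromethyl on an aromatic carbon puts hydrogen in place of trifluoromethyl on an aromatic carbon.

Among the measured compounds shown here, no measured step shows what this does, so a step in this assay beyond the scatter is not expected, in either direction. That expectation rests only on compound 3 with its limit of > 128000 nM and is weak.

In this assay compound 4 is expected at 100000 nM within an estimated range from 35000 nM to 128000 nM.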

Compound 4, half-maximal inhibitory concentration: > 128000 nM
Compound 4 gave a limit, no number; the forecaster's own chance of this, stated with the estimate: 60%; at least 1.2-fold (0.10 log units) between middle value and limit.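

In this assay compound 4 gives > 128000 nM, a limit of the assay and not a number. Among these compounds, compound 2 gives "not determined" (no result reported), so no step between compound 2 and compound 4 can be read. The compounds shown leave open what hydrogen in place of trifluoromethyl does in this assay.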